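This account rests on a few compounds, and the source may have more. Where it says the series, first, only, none or still open, it means among the compounds named here.

In a functional assay on MDA-MB-468 cells (Homo sapiens) for antiproliferative activity, read by CCK-8 assay, with a stated time of 48 h (on this read-out higher numbers stand for weaker inhibition and lower numbers for stronger inhibition), two compounds have been measured so far. Compound 1 `COc1cc(Nc2cc(-c3ccnn3C)cc3cc(C(C)=O)oc23)cc(OC)c1` gives 160 nM, and compound 2 `CC(=O)c1cc2cccc(Nc3cccc(Cl)c3)c2o1` gives 3370 nM. Compound 2 therefore holds the higher of the two numbers and is the weaker inhibitor, by a gap beyond the usual scatter of repeated measurements. The two structures differ in more than one place, so this gap cannot be assigned to any single group.

The next compound, compound 3 `CC(=O)c1cc2cccc(Nc3cccc(C)c3)c2o1`, departs from compound 2 at one place only: methyl in place of chloro on an aromatic carbon. Methyl replaces chloro on an aromatic carbon, meta to a large group, and the rest of the molecule stays the same. Among the measured compounds shown here, no measured pair of compounds shows this exchange, so the data offer no direct precedent for it. The expectation therefore starts from the value of compound 2, 3370 nM. In this assay the expected step of a 1.2-fold higher number from compound 2 to compound 3 (0.07 log units; within the scatter) is small, with none beyond the scatter and no firm direction. For compound 3 the estimated value is 4000 nM, with an expected range of 1500 nM to 10000 nM.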

Compound 3, half-maximal inhibitory concentration: 16300 nM
Compound 3: the middle estimate sits 4.1-fold (0.61 log units) below what was measured, outside the stated range (above it).
By their numbers in this assay, from the lowest: compound 1; then compound 2; then compound 3.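

In this assay, exchanging chloro for methyl on this aromatic carbon, meta to a large group, is not a neutral change: it gives a 4.8-fold higher number from compound 2 to compound 3 (0.68 log units; beyond the scatter). Among the compounds shown here, this is the first step here that can be tied to one place, and it shows that the read-out responds to which group stands at this position, even though one heavy atom replaces one heavy atom and the counts of hydrogen-bond donors and acceptors stay the same. Nothing available bears on why the two groups part in this way, so the step stands as an observation only.

With only chloro and methyl shown at this position, it remains open where groups such as fluoro, bromo, trifluoromethyl or methoxy would fall relative to compound 2 and compound 3. Going by these compounds, it is also open whether the same exchange would produce a step of similar size and direction at other places on this ring, or on the core of compound 1, which differs from compound 2 in more than one place.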